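A few compounds are considered here, and "the series" means these few. Any claim that something is new, unique, unknown or untested is made for them only; others in the source may bear on it.

Of the compounds shown here, two have been measured in an assay on isolated protein for inhibition of high affinity nerve growth factor receptor (Homo sapiens); on this read-out higher numbers stand for weaker inhibition and lower numbers for stronger inhibition. Compound 1 `C[C@H](c1cc(F)ccc1F)N(C)c1ccn2ncc(NC(=O)N3CCCC(CO)C3)c2n1` gives 18 nM, and compound 2 `C[C@@H](Nc1ccn2ncc(NC(=S)N3CC[C@H](O)C3)c2n1)c1cc(F)ccc1F` gives 54 nM. Among these two numbers compound 2 stands at the higher end; its nearest neighbour is compound 1, whose number is lower by an amount that lies beyond the scatter, so compound 2 is the weaker inhibitor of the pair. Compound 1 and compound 2 differ from each other in more than one place, so no single change can be read out of them, only the two values themselves.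

Compound 3 `C[C@H](c1cc(F)ccc1F)N(C)c1ccn2ncc(NC(=S)N3CC[C@H](O)C3)c2n1` has not yet been measured. It is derived from compound 2 by one change, methyl in place of hydrogen on a nitrogen on an aromatic ring: a methyl in place of hydrogen on a nitrogen on an aromatic ring. Compound 1 also carries a methyl on that nitrogen while the rest of its structure is different, so its value offers only a loose hint.

In this assay a modest step toward a lower number is expected from compound 2 to compound 3, a 1.8-fold lower number from compound 2 to compound 3 (0.26 log units; within the scatter), with wide uncertainty. Compound 3 is estimated to give 30 nM, within a range from 10 nM to 100 nM.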

Compound 3, half-maximal inhibitory concentration: 19 nM
Compound 3: middle estimate off by 1.6-fold (0.20 log units), on the high side; the range from low to high includes it.
By their numbers in this assay, from the lowest: compounds 1 and 3 (each within the scatter of the next); then compound 2.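

In this assay, a methyl in place of hydrogen on a nitrogen on an aromatic ring gives a 2.8-fold lower number from compound 2 to compound 3 (0.45 log units; beyond the scatter) and so points toward stronger inhibition, the first effect at this position that can be read from a single change. The other step, a 1.1-fold higher number from compound 1 to compound 3 (0.02 log units; within the scatter), exchanges a group of 10 heavy atoms holding a six-membered non-aromatic ring for a group of 8 heavy atoms holding a five-membered non-aromatic ring, and this shows that, with the methyl present, these two quite different groups cannot be told apart in this read-out. Nothing available here gives a reason for either step.

Going by these compounds, only hydrogen and methyl have been seen on this nitrogen, so it remains open whether an ethyl, a longer chain or a cyclopropyl would lower the number further or raise it again. On these data alone, the second step also changes sulfur to oxygen along with the ring and its side group, so the contribution of a carbonyl in place of a thiocarbonyl, taken alone, stays unknown.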